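A Second Chloro on the Amide Side of Compound 1

This account rests on a few compounds, and the source may have more. Where it says the series, first, only, none or still open, it means among the compounds named here.

Among the measured compounds shown here, compound 1 `O=C(/C=C/c1ccccc1)NCc1ccc(Cl)cc1` stands at the bottom of the two numbers measured so far. In a functional assay on the whole organism for inhibition, with Brassica rapa subsp. chinensis as the target, with a stated time of 3 days, tested at 100 ppm (a lower number here means less inhibition of growth, a higher number more inhibition of growth at the concentration tested), compound 1 gives 6%, while compound 2 `Cc1ccc(OC(=O)/C=C/c2ccc(C(C)C)cc2)c(C(C)C)c1` gives 39%, a gap that lies beyond the scatter. Compound 3 `O=C(/C=C/c1ccccc1)NCc1ccc(Cl)cc1Cl` differs from compound 1 by chloro in place of hydrogen on an aromatic carbon. For the measured compounds named here, no measured pair shows a change of this kind, so its effect cannot be read from the data. A small rise, if any, is expected: the expected step is a number 9 percentage points higher from compound 1 to compound 3 (within the scatter), which could still fall within the scatter. Compound 3 is expected to give 15%, in a range from 0% to 40%.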

Compound 3, percent growth inhibition at one concentration: 0%
Compound 3: middle estimate off by 15 percentage points, on the high side; low and high end bracket the measured number.
By their numbers in this assay, from the lowest: compounds 3 and 1 (each within the scatter of the next); then compound 2.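

In this assay, this first measured example of the change gives a number 6 percentage points lower from compound 1 to compound 3 (within the scatter). Placing chloro in place of hydrogen on this aromatic carbon, ortho to a large group and meta to a chloro group, therefore does not separate the two compounds, and both show little inhibition of growth at the concentration tested. Nothing available explains this result. Still open, from the compounds shown here alone, is whether a different group at this position, such as an amine, a methoxy group or a carboxylic acid, would change the inhibition of growth. The compounds shown also leave open whether chloro would behave the same way on another carbon of this ring.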